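This account rests on a few compounds, and the source may have more. Where it says the series, first, only, none or still open, it means among the compounds named here.

Measured in a functional assay on SF-295 cells (Homo sapiens) for inhibition, read by sulforhodamine B assay, with a stated time of 48 h; on this read-out lower numbers stand for stronger inhibition of growth and higher numbers for weaker inhibition of growth:
- compound 1 `O=C(Cc1csc2nc(-c3ccc(Br)cc3)cn12)N/N=C/c1ccccc1`: 37200 nM
- compound 2 `O=C(Cc1csc2nc(-c3ccc(Br)cc3)cn12)N/N=C/c1ccc(O)cc1`: 41700 nM
- compound 3 `COc1cccc(OC)c1/C=N/NC(=O)Cc1csc2nc(-c3ccc(Br)cc3)cn12`: 34700 nM

Compound 3 does not separate from the other two compounds. The series shows a 1.1-fold lower number from compound 1 to compound 3 (0.03 log units; within the scatter) and a 1.2-fold lower number from compound 2 to compound 3 (0.08 log units; within the scatter) on the same read-out, so its value sits among theirs rather than apart from them.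

The next compound is compound 4 `O=C(Cc1csc2nc(-c3ccc(Br)cc3)cn12)N/N=C/c1ccc(Cl)cc1Cl`, which carries 2,4-dichlorophenyl in place of 2,6-dimethoxyphenyl on a carbon with a double bond to nitrogen. The difference counts as 2,4-dichlorophenyl in place of 2,6-dimethoxyphenyl on a carbon with a double bond to nitrogen and leaves the rest of the structure unchanged.

All three measured steps bear on this change, since each alters only the aromatic group at this place. Besides the two steps to compound 3, there is a 1.1-fold higher number from compound 1 to compound 2 (0.05 log units; within the scatter) in this assay as well. None of them leaves the scatter. However, no measured compound has chlorine on this group, so the evidence is indirect. No step beyond the scatter is therefore expected, in either direction.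

The estimated step is a 1.0-fold higher number from compound 3 to compound 4 (0.02 log units; within the scatter) and it would stay within the scatter. Compound 4 is expected at about 36000 nM, with an estimated range from 21000 nM to 60000 nM in this read-out.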

Compound 4, concentration for total growth inhibition: > 100000 nM
Compound 4: no number, only a limit; the forecaster's own chance of this, stated with the estimate: 10%; middle value at least 2.7-fold (0.44 log units) away from the limit.
By their numbers in this assay, from the lowest: compounds 3, 1 and 2 (each within the scatter of the next). At a limit, above all of these: compound 4.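

In this assay, the aromatic group on the carbon with a double bond to nitrogen proves less indifferent than compound 1, compound 2 and compound 3 suggested, and 2,4-dichlorophenyl is the one group shown that gives steps beyond the scatter: an at least 2.8-fold higher number from compound 3 to compound 4 (0.45 log units; beyond the scatter), an at least 2.3-fold higher number from compound 2 to compound 4 (0.37 log units; beyond the scatter) and an at least 2.6-fold higher number from compound 1 to compound 4 (0.42 log units; beyond the scatter). From the compounds shown here alone, compound 4 has no number here, only a limit, so the full size of these steps stays unknown and they can be read in one direction only, towards weaker inhibition of growth: the limit of > 100000 nM in this assay, at which 1 of the 4 values shown sits. Phenyl, 4-hydroxyphenyl and 2,6-dimethoxyphenyl remain within the scatter of one another, so this position accepts those three groups alike, and only 2,4-dichlorophenyl departs from them.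

The compounds shown leave open whether a phenyl group with a single chlorine would give the same result or whether both chlorine atoms are needed. They also leave open how this position would read with a phenyl group carrying fluorine, a methyl group or an amine.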